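This account rests on a few compounds, and the source may have more. Where it says the series, first, only, none or still open, it means among the compounds named here.

Compound 1, `CC(=O)CC[C@]1(C(C)=O)C(=O)O[C@@H](OC(C)=O)[C@H]1C`: in a functional assay on DA-3 cells for cytotoxicity against DA-3 cell line (Mus musculus), read by MTT assay (on this read-out lower numbers stand for stronger inhibition and higher numbers for weaker inhibition), compound 1 gives 8000 nM.
Compound 2, `CC(=O)O[C@@H]1OC(=O)[C@@](C(C)=O)(C2SCCCS2)[C@@H]1C`: in this assay compound 2 reaches only a limit of the assay, > 50000 nM.
Compound 3, `CC(=O)O[C@@H]1OC(=O)[C@](O)(C(C)=O)[C@@H]1C`: in this assay compound 3 likewise reaches only a limit of the assay, > 50000 nM.

Compound 3 therefore stands at the weak end of what the numbers show, a position it shares with compound 2, since (the limit of > 50000 nM in this assay, at which 2 of the 3 values shown sit). Among the compounds with values here, the only readable steps both start from compound 1: an at least 6.2-fold higher number from compound 1 to compound 2 (0.79 log units; beyond the scatter) and an at least 6.2-fold higher number from compound 1 to compound 3 (0.79 log units; beyond the scatter). Between the two limit compounds, a step that the two limits leave unreadable from compound 2 to compound 3.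

Compound 4, `CC(=O)O[C@@H]1OC(=O)[C@](Br)(C(C)=O)[C@@H]1C`, differs from compound 3 in one place: bromo in place of hydroxy on a saturated ring carbon. Within the data shown here, no measured step swaps hydroxy for bromo, or for any other single atom, so nothing among the measured compounds speaks directly to this change. The steps that are readable only show that compound 3 starts from a limit, and a move from a limit cannot be sized in either direction with any confidence.

Among the measured compounds shown here, the expectation for compound 4 is accordingly no step that can be called beyond the scatter, an at least 1.6-fold lower number from compound 3 to compound 4 (0.22 log units; that floor lies within the scatter), with a wide spread. Compound 4 is estimated at 30000 nM, in a range from 5000 nM to 100000 nM.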

Compound 4, half-maximal inhibitory concentration: 6000 nM
Compound 4: middle estimate off by 5.0-fold (0.70 log units), on the high side; low and high end bracket the measured number.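

In this assay, this saturated ring carbon proves sensitive to a change of a single atom: swapping hydroxy for bromo gives an at least 8.3-fold lower number from compound 3 to compound 4 (0.92 log units; beyond the scatter), and bromine in place of the larger group with its six-membered ring gives an at least 8.3-fold lower number from compound 2 to compound 4 (0.92 log units; beyond the scatter). Set against the 2-acetylethyl chain, bromo gives a 1.3-fold lower number from compound 1 to compound 4 (0.12 log units; within the scatter), so one bromine atom and that whole chain cannot be told apart here, even though hydroxy and the six-membered ring group both leave the compound at the weak end. Both lower steps are floors rather than measured sizes, and the real gaps could be larger: the limit of > 50000 nM in this assay, at which 2 of the 4 values shown sit.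

The compounds shown leave open whether this effect belongs to bromo in particular or would also appear with chloro, iodo, an amine or a methoxy group on the same carbon. They also leave open how much the result depends on the acetoxy and methyl groups on the ring, which all four compounds carry unchanged, and whether a different ester, such as a benzoate, would keep the activity of compound 4.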